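Working notes: urea aryl swap in a cytotoxicity series

The source may hold more compounds than are shown below. What is called first, only, known or untested is meant among the compounds shown, and "the series" means these compounds.

Measured so far:
compound 1 `O=C(Nc1cccc(-n2cc(-c3ccncc3)c(-c3ccc(Cl)c(O)c3)n2)c1)Nc1cccc(C(F)(F)F)c1` — > 32500 nM
compound 2 `COc1cc(-c2nn(-c3cccc(NC(=O)Nc4ccc(Cl)c(Cl)c4)c3)cc2-c2ccncc2)ccc1Cl` — > 50000 nM

In a functional assay on A498 cells (Homo sapiens) for inhibition, read by sulforhodamine B assay, with a stated time of 48 h (a lower number here means that less compound is tolerated, a higher number that more compound is tolerated), compound 1 gives > 32500 nM, which is a limit of the assay and not a number. Compound 2 in this assay gives > 50000 nM, likewise a limit only. Compound 2 therefore stands at one of the two limits shown, (the limit of > 50000 nM in this assay, at which 1 of the 2 values shown sits), while the other value sits at the limit of > 32500 nM in this assay, at which 1 of the 2 values shown sits; neither value allows an order between the two compounds to be read.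

Compound 3 `COc1cc(-c2nn(-c3cccc(NC(=O)Nc4cccc(C(F)(F)F)c4)c3)cc2-c2ccncc2)ccc1Cl` differs from compound 2 by 3-(trifluoromethyl)phenyl in place of 3,4-dichlorophenyl on an amide-type nitrogen. Among the compounds with values here, no measured step covers this change. Within the data shown here, since both values shown are limits, no size of step in this assay can be derived from them, and for compound 3 no movement beyond the scatter is expected. The step from compound 2 to compound 3 is estimated as a number no higher from compound 2 to compound 3 (the limit leaves the size open), meaning no change. Compound 3 is expected to give about 50000 nM in this assay, with a range from 20000 nM to 100000 nM, most likely reported as a limit again.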

Compound 3, concentration lethal to 50% of the cells: > 50000 nM
Compound 3: only a limit was reported; the forecaster's own chance of this, stated with the estimate: 85%; the middle value lies on the limit itself.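

No new step can be read for compound 3 against compound 2 or compound 1: all three values in this assay are limits of the assay and not numbers. The compounds shown leave open whether 3-(trifluoromethyl)phenyl in place of 3,4-dichlorophenyl, or methyl in place of hydrogen on the oxygen, shifts the lethal concentration at all.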